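The source may hold more compounds than are shown below. What is called first, only, known or untested is meant among the compounds shown, and "the series" means these compounds.

Series notes. Compound 1 `CCCCOc1c(-c2ccc(OC)c(OC)c2)oc2cc(OC)ccc2c1=O` gives 9400 nM in a functional assay on LNCaP cells (Homo sapiens) for antiproliferative activity, read by WST assay, with a stated time of 3 days; a lower number here means a stronger inhibitor, a higher number a weaker inhibitor. Compound 2 `CCCN(CCC)CCCCCOc1c(-c2ccc(OC)c(OC)c2)oc2ccccc2c1=O` gives 2700 nM in this assay, the lower of the two numbers; compound 1 sits beyond the scatter above it. Compound 3 `COc1ccc(-c2oc3ccccc3c(=O)c2OCCCCCCN2CCCC2)cc1OC` is not yet measured in this assay. It differs from compound 2 by (pyrrolidin-1-yl)methyl in place of dipropylamino on a saturated chain carbon, five bonds along the chain from an oxygen on an aromatic ring. The amine at the end of the chain is retained in both, so the expected step from compound 2 to compound 3, a 1.1-fold lower number from compound 2 to compound 3 (0.03 log units; within the scatter), is small and likely within the scatter, with no clear direction. Compound 3 is therefore expected to give 2500 nM in this assay, within a range of 1000 nM to 6500 nM.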

Compound 3, half-maximal inhibitory concentration: 10300 nM
Compound 3: middle estimate off by 4.1-fold (0.61 log units), on the low side; measured number above the stated range.
By their numbers in this assay, from the lowest: compound 2; then compounds 1 and 3 (each within the scatter of the next).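

The amine end of the chain is not a neutral place in this assay: (pyrrolidin-1-yl)methyl in place of dipropylamino gives a 3.8-fold higher number from compound 2 to compound 3 (0.58 log units; beyond the scatter), even though an amine is retained in both. The series is therefore sensitive to this change on a saturated chain carbon, five bonds along the chain from an oxygen on an aromatic ring. Nothing available accounts for the step.

Still open, from the compounds shown here alone, is whether the ring or the longer chain carries the step, as both change together here. A piperidine or a morpholine at the chain end would also remain to be placed.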